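Swapping the aryl group on the carbonyl of compound 1

A few compounds are considered here, and "the series" means these few. Any claim that something is new, unique, unknown or untested is made for them only; others in the source may bear on it.

Measured compounds:
compound 1, `COc1ccc(/C=C/c2cc(OC)cc(OC)c2/C=C/C(=O)c2cccc(OC)c2)cc1`: 4.3 ug/mL
compound 2, `COc1ccc(/C=C/c2cc(OC)cc(OC)c2/C=C/C(=O)c2ccc(N)cc2)cc1`: 2.8 ug/mL
compound 3, `COc1ccc(/C=C/c2cc(OC)cc(OC)c2/C=C/C(=O)c2ccc(F)cc2)cc1`: 5.3 ug/mL

Three compounds share one core and differ only in the aryl group on the carbonyl carbon. In a functional assay on B16-F10 cells (Mus musculus) for antiproliferative activity, read by MTT assay, with a stated time of 48 h (a lower number here means a stronger inhibitor, a higher number a weaker inhibitor), compound 1 gives 4.3 ug/mL, the second highest of the three numbers; its nearest neighbour is compound 3 with 5.3 ug/mL, and its furthest is compound 2 with 2.8 ug/mL. Both gaps lie within the usual scatter, so none of the three can be called stronger or weaker than another.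

Compound 4, `COc1ccc(/C=C/c2cc(OC)cc(OC)c2/C=C/C(=O)c2ccccc2C)cc1`, is not yet measured. It differs from compound 1 in one place: 2-methylphenyl in place of 3-methoxyphenyl on a carbonyl carbon. Going by the values given here, the steps that bear on this are the two other replacements at the same carbonyl carbon, a 1.5-fold lower number from compound 1 to compound 2 (0.19 log units; within the scatter) and a 1.2-fold higher number from compound 1 to compound 3 (0.09 log units; within the scatter), both within the scatter. Exchanging one aryl group for another here has so far left the number essentially unchanged, so for compound 4 a step of no more than the scatter is expected in this assay, in no particular direction, as a 1.0-fold higher number from compound 1 to compound 4 (0.02 log units; within the scatter).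

Compound 4 is therefore estimated at 4.5 ug/mL, with a range from 2.3 ug/mL to 9 ug/mL.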

Compound 4, half-maximal inhibitory concentration: 6.1 ug/mL
Estimate against measurement, compound 4: 1.4-fold (0.13 log units) below, and the stated range covers the measured number.
By their numbers in this assay, from the lowest: compounds 2, 1, 3 and 4 (each within the scatter of the next, the first and the last beyond it).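

In this assay the change from 3-methoxyphenyl to 2-methylphenyl gives a 1.4-fold higher number from compound 1 to compound 4 (0.15 log units; within the scatter), and the change from 4-fluorophenyl to 2-methylphenyl gives a 1.2-fold higher number from compound 3 to compound 4 (0.06 log units; within the scatter), so this carbonyl carbon also accepts an aryl group with no hydrogen-bond acceptor without a readable shift from either compound. Going by these compounds alone, the comparison with the amino compound is the first to clear the scatter, with a 2.2-fold higher number from compound 2 to compound 4 (0.34 log units; beyond the scatter), which shows that the choice of aryl group at this position can separate two compounds, though only modestly and only for this one pair, since compound 1 and compound 3 remain within the scatter of both. Nothing available here explains why this one pair separates.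

The compounds shown all carry an aryl group at this position, so it remains open whether a group without such a ring, such as a cyclohexyl ring or a short alkyl chain, would give a similar number. On these data alone, it is also open whether the gap between compound 2 and compound 4 would widen with a different group on the ring, such as a carboxylic acid or a dimethylamino group.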